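The compounds below may be only part of what the source reports. "The series", "measured", "known", "first", "only" and "open" are said of these compounds alone.

Compound 1 `CCC(=O)c1ccc(N(C)C(=O)CSc2nnc(CNc3ccccc3)n2CC)cc1` gives 2000 nM in an assay on isolated protein for inhibition of long-chain fatty acid transport protein 1 (Mus musculus); a higher number here means a weaker inhibitor, a lower number a stronger inhibitor. Compound 2 `CCc1ccc2oc(CSc3nnc(CNc4ccccc4)n3CC)nc2c1` gives 1800 nM in this assay. Compound 3 `CCOC(=O)c1ccc(NC(=O)CSc2nnc(CSCc3ccccc3)n2CC)cc1` gives only a limit in this assay, > 10000 nM.

Among the two numbers that are not limits, compound 2 carries the lower one, but compound 1 sits so close to it that the two lie within the scatter of repeated measurements, so no order between them can be claimed. Compound 3 stands at a limit of the assay (the limit of > 10000 nM in this assay, at which 1 of the 3 values shown sits), and nothing more can be read from it.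

Compound 4 `CCn1c(CNc2ccccc2)nnc1SCc1nc2cc(C)ccc2o1` differs from compound 2 by one change: hydrogen in place of methyl on a saturated chain carbon bound to an aromatic carbon, which cut one bond further out reads ethyl to methyl. Among the compounds with values here, no pair of measured compounds isolates this change, so no measured step shows what it does. A shortening of a chain by one carbon of this kind is expected to move the number little, if at all; the step from compound 2 to compound 4 is expected to stay within the scatter, a 1.2-fold higher number from compound 2 to compound 4 (0.09 log units; within the scatter), perhaps leaning toward a slightly higher number. Compound 4 is therefore estimated at 2200 nM in this assay, with a range from 900 nM to 5500 nM.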

Compound 4, half-maximal inhibitory concentration: > 10000 nM
Compound 4: no number, only a limit; the forecaster's own chance of this, stated with the estimate: 5%; at least 4.5-fold (0.65 log units) between middle value and limit.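

Shortening ethyl to methyl at this place, on a saturated chain carbon bound to an aromatic carbon, gives an at least 5.5-fold higher number from compound 2 to compound 4 (0.74 log units; beyond the scatter) in this assay. Within the data shown here, the earlier compounds offered no pair that differed in one place, so this is the only step that can be read, and it shows that a single carbon at this position is enough to move the number beyond the scatter. Compound 4 gives only a limit, so the step has a floor and no known upper end: the limit of > 10000 nM in this assay, at which 2 of the 4 values shown sit.

The compounds shown leave open whether a longer chain such as propyl, or a branched one such as isopropyl, at this place would give a lower number than compound 2 does. They also leave open how far the number depends on chain length here, and whether a group such as methoxy would fare as ethyl does.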